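Removing the nitro group while keeping the sulfonyl

This account rests on a few compounds, and the source may have more. Where it says the series, first, only, none or still open, it means among the compounds named here.

Measured so far:
compound 1, `O=[N+]([O-])c1cc(S(=O)(=O)C(Cl)(Cl)Br)ccc1NC1CCCCC1`: 4000 nM
compound 2, `O=[N+]([O-])c1ccccc1NC1CCCCC1`: > 1000000 nM

Among the measured compounds shown here, in an assay on cells for inhibition of serine/threonine-protein kinase WNK1 (Homo sapiens), read by luminescence and Kinase-Glo, with a stated time of 2 h (on this read-out higher numbers stand for weaker inhibition and lower numbers for stronger inhibition), compound 1 gives 4000 nM, the only actual number in the set. Compound 2 reaches only the limit of the assay, > 1000000 nM. Taken together these give an at least 250-fold higher number from compound 1 to compound 2 (2.39 log units; beyond the scatter), a change that strips the sulfonyl group while the nitro group stays; this is the basis for (the limit of > 1000000 nM in this assay, at which 1 of the 2 values shown sits).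

Compound 3, `O=S(=O)(c1ccc(NC2CCCCC2)cc1)C(Cl)(Cl)Br`, goes the other way: hydrogen in place of nitro on an aromatic carbon. For the measured compounds named here, the one measured step concerns the sulfonyl group, not the nitro group, so it does not bear on this change; no measured step speaks to the nitro group at all. For compound 3 the number is therefore estimated at 8000 nM, with a range of 1500 nM to 60000 nM. This estimate amounts to an expected 2.0-fold higher number from compound 1 to compound 3 (0.30 log units; within the scatter), a step held close to the scatter for lack of any evidence pointing elsewhere.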

Compound 3, half-maximal inhibitory concentration: > 1000000 nM
Compound 3 ended at the assay's limit; the forecaster's own chance of this, stated with the estimate: 15%; middle value at least 120-fold (2.09 log units) away from the limit.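

In this assay the nitro group ortho to the cyclohexylamino group proves necessary for a measurable value in this pair: hydrogen in its place gives an at least 250-fold higher number from compound 1 to compound 3 (2.39 log units; beyond the scatter) and the (bromo(dichloro)methyl)sulfonyl group alone therefore does not preserve the inhibition seen for compound 1. Compound 3 gives > 1000000 nM as a limit of the assay and not a number, so the step has a lower bound only. Among the compounds shown, only compound 1 carries both groups and only compound 1 has an actual number, while losing either group leads to the same limit: the limit of > 1000000 nM in this assay, at which 2 of the 3 values shown sit.

Going by these compounds, whether an amine or a nitrile in place of the nitro group would retain inhibition remains open. On these data alone, it is equally open whether a carboxylic acid could stand in for the (bromo(dichloro)methyl)sulfonyl group.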